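This account rests on a few compounds, and the source may have more. Where it says the series, first, only, none or still open, it means among the compounds named here.

Measured compounds:
- compound 1, `CC(C)[C@@H](CC(=O)O)NC(=O)[C@@H]1CCCN1S(=O)(=O)c1cc(Cl)cc(Cl)c1`, in an assay on RPMI-8866 cells for inhibition of integrin alpha-4/beta-1 (Homo sapiens) (a lower number here means a stronger inhibitor, a higher number a weaker inhibitor), compound 1 gives 8.9 nM
- compound 2, `O=C(O)C[C@@H](NC(=O)[C@@H]1CCN1S(=O)(=O)c1cc(Cl)cc(Cl)c1)c1ccc(F)cc1`, in this assay compound 2 gives 3.2 nM

Of the two numbers, compound 2 holds the lower one, and compound 1 stands apart from it by a gap that is beyond the usual scatter. The two compounds differ in more than one place, so nothing is said about which part of the structure accounts for that gap.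

The account now turns to compound 3, `O=C(O)C[C@@H](NC(=O)[C@@H]1CCN1S(=O)(=O)c1cc(Cl)cc(Cl)c1)c1ccc(OC(F)F)cc1`, which is not yet measured in this assay. It is the direct partner of compound 2: the only difference is difluoromethoxy in place of fluoro on an aromatic carbon. Among the compounds with values here, no pair of measured compounds shows this same change, so there is no measured step to lean on. With only the value of compound 2, 3.2 nM, as anchor, the step is expected to stay small, plausibly within the scatter, with no direction that can be stated with confidence. Compound 3 is therefore estimated at 4 nM, in a range from 1.5 nM to 12 nM, which corresponds to an expected 1.3-fold higher number from compound 2 to compound 3 (0.10 log units; within the scatter).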

Compound 3, half-maximal inhibitory concentration: 1.3 nM
For compound 3 the middle estimate is 3.1-fold (0.49 log units) above the measured one; measured number below the stated range.
By their numbers in this assay, from the lowest: compound 3; then compound 2; then compound 1.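

In this assay, putting difluoromethoxy in place of fluoro on an aromatic carbon, para to a large group, gives a 2.5-fold lower number from compound 2 to compound 3 (0.39 log units; beyond the scatter), a modest step but one beyond the scatter. Within the data shown here, this is the first comparison that differs in only one place, and it shows that this position accepts the larger difluoromethoxy group, which brings an oxygen and a hydrogen-bond acceptor, with no loss in this read-out and in fact a lower number. Nothing available accounts for this step, so the finding remains a measured difference with no established cause.

Going by these compounds, the step rests on a single pair on the core of compound 2, so it remains open whether the same change would give a similar step on a different core. Methoxy and trifluoromethoxy groups are not among the compounds shown, leaving it unclear whether the oxygen, the fluorines or their combination goes with the lower number, and how a hydroxyl or an amine would fare at this position.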